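Shortening the alkylamino chain: cytotoxicity in kidney cells

This account rests on a few compounds, and the source may have more. Where it says the series, first, only, none or still open, it means among the compounds named here.

Measured so far, in an ADME assay on MDCK cells (Canis lupus familiaris) for cytotoxicity, read by microscopy, with a stated time of 6 days; on this read-out higher numbers stand for lower toxicity in this test and lower numbers for higher toxicity in this test:
- compound 1, `CCCCCCCCNc1cncc(C(=O)NCc2ccccc2)n1`: 4000 nM
- compound 2, `CCCCCCCNc1cncc(C(=O)NCc2ccccc2)n1`: 4000 nM

Compound 2 stands level with compound 1 at the digits shown; the step of no change at the digits printed from compound 1 to compound 2 (within the scatter) lies within the scatter. Compound 3 `CCCCCNc1cncc(C(=O)NCc2ccccc2)n1` differs from compound 2 by hydrogen in place of ethyl on a saturated chain carbon, five bonds along the chain from a nitrogen on an aromatic ring. Among the measured compounds shown here, the only measured step that bears on this change is no change at the digits printed from compound 1 to compound 2 (within the scatter), a smaller cut of the same kind on the same chain, with no movement beyond the scatter. On that basis no step beyond the scatter is expected in this assay for compound 3, which is estimated at 4000 nM with a range of 2000 nM to 8000 nM, an expected step of no change at the digits printed from compound 2 to compound 3 (within the scatter).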

Compound 3, minimum cytotoxic concentration: 20000 nM
For compound 3 the middle estimate is 5.0-fold (0.70 log units) below the measured one, outside the stated range (above it).
By their numbers in this assay, from the lowest: compounds 1 and 2 (each within the scatter of the next); then compound 3.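

In this assay, the chain length is not without consequence at this place: hydrogen in place of ethyl gives a 5.0-fold higher number from compound 2 to compound 3 (0.70 log units; beyond the scatter), a move the smaller cut on the same chain did not show. Hydrogen in place of propyl gives the matching a 5.0-fold higher number from compound 1 to compound 3 (0.70 log units; beyond the scatter), so the higher number, meaning lower toxicity in this test, appears only with the pentyl chain of compound 3. No measurement shown explains this step.

Open, going by these compounds, is whether a hexyl chain already gives the higher number. Also open, on these data alone, is whether a shorter propyl chain, or a chain ending in an amine or a carboxylic acid, would raise it further.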